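The source may hold more compounds than are shown below. What is called first, only, known or untested is meant among the compounds shown, and "the series" means these compounds.

Two sulfonamides share a common core and have been measured in a functional assay on OVCAR-3 cells (Homo sapiens) for antiproliferative activity, read by MTT assay, with a stated time of 24 h; a higher number here means a weaker inhibitor, a lower number a stronger inhibitor. Compound 1 `Cc1cccc(-n2cc(-c3ccccc3NS(=O)(=O)c3c[nH]c(=O)[nH]c3=O)nn2)c1` gives 3150 nM in this assay. Compound 2 `O=c1[nH]cc(S(=O)(=O)Nc2ccc(-c3cn(-c4ccccc4)nn3)cc2)c(=O)[nH]1` gives 18000 nM in this assay, which is the higher of the two numbers, and the number for compound 1 lies lower by a margin beyond the usual scatter. For the measured compounds named here, the two compounds differ in more than one place, so no single structural step connects them and their two values are simply recorded side by side.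

Compound 3 `Cc1ccccc1-n1cc(-c2ccc(NS(=O)(=O)c3c[nH]c(=O)[nH]c3=O)cc2)nn1` has not yet been measured. It differs from compound 2 by methyl in place of hydrogen on an aromatic carbon. Going by the values given here, with no directly comparable step among the measured compounds, the expected change from compound 2 to compound 3 is estimated as a 1.5-fold lower number from compound 2 to compound 3 (0.18 log units; within the scatter), a shift that may not exceed the scatter. Compound 3 is therefore expected to give about 12000 nM, within a range of 5000 nM to 30000 nM.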

Compound 3, half-maximal inhibitory concentration: 7310 nM
Estimate against measurement, compound 3: 1.6-fold (0.22 log units) above; low and high end bracket the measured number.
By their numbers in this assay, from the lowest: compound 1; then compound 3; then compound 2.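

For the compounds shown here, the change from phenyl to 2-methylphenyl is the first step in this set that can be read at a single place: in this assay it gives a 2.5-fold lower number from compound 2 to compound 3 (0.39 log units; beyond the scatter), a modest change. It shows that a methyl on this aromatic carbon, ortho to a large group, is accepted here and moves the number towards stronger inhibition rather than weaker. No measurement at hand accounts for this shift.

Going by these compounds, what remains open is whether a larger or different group at the same position, such as ethyl, methoxy, chlorine or an amine, would continue this shift or reverse it. Compound 1 differs from compound 3 in more than one place, so it cannot show whether the methyl step would hold on another ring position or with another arrangement of the core.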